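The source may hold more compounds than are shown below. What is called first, only, known or untested is meant among the compounds shown, and "the series" means these compounds.

Measured compounds in a functional assay on NCI-H226 cells (Homo sapiens) for inhibition, read by MTT assay, with a stated time of 48 h, tested at 10 uM; a higher number here means more inhibition at the concentration tested (going by the name of the read-out), a lower number less inhibition:
- compound 1, `COc1cc(NC(=O)Nc2cc(Nc3ccc(F)c(Cl)c3)ncn2)cc(OC)c1`, gives 36.7%
- compound 2, `COc1ccc(Nc2cc(NC(=O)Nc3c(Cl)cccc3Cl)ncn2)cc1C`, gives 50%
- compound 3, `CCc1cccc(Nc2cc(NC(=O)Nc3cc(OC)cc(OC)c3)ncn2)c1`, gives 36.7%

Compound 3 stands level with compound 1 at the digits printed, the two together forming the lowest pair of the three numbers; compound 2 stands higher, beyond the scatter, though its urea partner is a different aryl group, so the two values are not linked by a single change.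

Compound 4, `COc1cc(NC(=O)Nc2cc(Nc3ccc(OC)c(C)c3)ncn2)cc(OC)c1`, differs from compound 3 in one place: 4-methoxy-3-methylphenyl in place of 3-ethylphenyl on a nitrogen on an aromatic ring. For the measured compounds named here, the only measured step at this position is no change at the digits printed from compound 1 to compound 3 (within the scatter), where swapping one aryl group for another on the same nitrogen left the read-out unchanged. Compound 2 carries the same 4-methoxy-3-methylphenyl group on that nitrogen and gives a somewhat higher number, but with a different urea aryl, so it bears on compound 4 only loosely. The step from compound 3 to compound 4 is therefore expected to be small, a number 3.3 percentage points higher from compound 3 to compound 4 (within the scatter), with perhaps a slight upward lean. Compound 4 is estimated at 40%, within a range of 25% to 55%.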

Compound 4, a percentage reported as inhibition, at one concentration (the size of the read-out at that concentration, not a potency): 39.7%
Compound 4: the middle estimate sits 0.3 percentage points above what was measured; the measured number falls inside the stated range.
By their numbers in this assay, from the lowest: compounds 1, 3 and 4 (each within the scatter of the next); then compound 2.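

In this assay the change to 4-methoxy-3-methylphenyl on a nitrogen on an aromatic ring gives a number 3 percentage points higher from compound 3 to compound 4 (within the scatter) and a number 3 percentage points higher from compound 1 to compound 4 (within the scatter) so with three aryl groups now read at this place, the number still does not separate them. For the compounds shown here, the urea aryl gives the first single-place comparison at the amide-type nitrogen: with 4-methoxy-3-methylphenyl held fixed, 3,5-dimethoxyphenyl in place of 2,6-dichlorophenyl gives a number 10.3 percentage points lower from compound 2 to compound 4 (beyond the scatter) and so this modest step, not the change at the other nitrogen, is what separates these compounds. No measurement at hand accounts for either result.

On these data alone, whether the urea aryl step holds with other groups on the aromatic-ring-bound nitrogen remains open, since it rests on a single pair. Also open, as far as these compounds go, is whether an aryl group carrying a morpholine or a carboxylic acid, at either nitrogen, would move the read-out further.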